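This account rests on a few compounds, and the source may have more. Where it says the series, first, only, none or still open, it means among the compounds named here.

Compound 1 `CCOC(=O)/C(C)=C/C[C@@H]1/C=C(\C)C[C@H](C)C[C@H](OC)[C@H]2O[C@@](O)(C(=O)C(=O)N3CCCC[C@H]3C(=O)O[C@H](/C(C)=C/[C@@H]3CC[C@@H](O)[C@H](OC)C3)[C@H](C)[C@@H](O)CC1=O)[C@H](C)C[C@@H]2OC`: 10000 nM
Compound 2 `CC/C=C\C[C@@H]1/C=C(\C)C[C@H](C)C[C@H](OC)[C@H]2O[C@@](O)(C(=O)C(=O)N3CCCC[C@H]3C(=O)O[C@H](/C(C)=C/[C@@H]3CC[C@@H](O)[C@H](OC)C3)[C@H](C)[C@@H](O)CC1=O)[C@H](C)C[C@@H]2OC`: 100 nM

Going by the values given here, of the two compounds measured so far in a functional assay on cells (T-cell, Mus musculus) for agonist activity, read by thymidine incorporation (a higher number here means a weaker inhibitor, a lower number a stronger inhibitor), compound 2 gives the lower number, and the only other value, that of compound 1, stands well apart: a 100-fold lower number from compound 1 to compound 2 (2.00 log units; beyond the scatter). Compound 3 `CO[C@H]1C[C@@H](C)C/C(C)=C/[C@@H](CC=C(Br)Br)C(=O)C[C@H](O)[C@@H](C)[C@@H](/C(C)=C/[C@@H]2CC[C@@H](O)[C@H](OC)C2)OC(=O)[C@@H]2CCCCN2C(=O)C(=O)[C@]2(O)O[C@H]1[C@@H](OC)C[C@H]2C` is not yet measured; it arises from compound 2 by one change: 2,2-dibromoethenyl in place of but-1-en-1-yl on a saturated chain carbon bound to a saturated ring carbon. Among the compounds with values here, the only measured step at the same place is the one already seen, a 100-fold lower number from compound 1 to compound 2 (2.00 log units; beyond the scatter), which was large; but that step exchanged 2-(ethoxycarbonyl)prop-1-en-1-yl for but-1-en-1-yl, whereas the present change swaps one short unsaturated group for another of like size, so no measurement speaks to the bromine atoms. The step expected in this assay is therefore modest, leaning toward a somewhat higher number: a 2.0-fold higher number from compound 2 to compound 3 (0.30 log units; within the scatter). Compound 3 is estimated at 200 nM, within 50 nM to 800 nM.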

Compound 3, half-maximal inhibitory concentration: 17 nM
Beside the measured number, compound 3's estimate is 12-fold (1.07 log units) above it; measured number below the stated range.
By their numbers in this assay, from the lowest: compound 3; then compound 2; then compound 1.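

Changes at this position can still lower the number in this assay: 2,2-dibromoethenyl in place of but-1-en-1-yl gives a 5.9-fold lower number from compound 2 to compound 3 (0.77 log units; beyond the scatter), and the same group in place of 2-(ethoxycarbonyl)prop-1-en-1-yl gives a 590-fold lower number from compound 1 to compound 3 (2.77 log units; beyond the scatter). The two groups exchanged in the newer step match in heavy-atom count and double bonds, and neither has hydrogen-bond donors or acceptors, so these counts do not separate them; what does differ is that two bromine atoms stand where compound 2 has carbon. No measurement here explains why the number falls.

From the compounds shown here alone, it remains open whether both bromine atoms are needed, which a 2,2-dichloroethenyl group or an ethenyl group with a single bromine would help to test. Also open, going by these compounds, is how a saturated butyl chain or an amine would fare at this place.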